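The compounds below may be only part of what the source reports. "The series", "measured", "known", "first", "only" and "open" are said of these compounds alone.

Compound 1, `Cc1c(C2=NOC(C)(C)C2=O)cccc1-c1cnc(NC(=O)c2c(F)cccc2F)cn1`, gives 55 nM in an assay on Jurkat T cells for inhibition of interleukin-2 (Homo sapiens), read by ELISA, with stated times of 10 min and 24 h; on this read-out higher numbers stand for weaker inhibition and lower numbers for stronger inhibition. Compound 2, `Cc1ccc(C2=NOC(C)(C)C2=O)cc1-c1cnc(C(=O)Nc2c(F)cccc2F)cn1`, gives 150 nM in this assay. Compound 3, `Cc1ccc(C2=NOC(C)(C)C2=O)cc1-c1cnc(NC(=O)c2ccc(F)cc2F)cn1`, is reported in this assay as "not active" (no number reported), with no number given.

All three were tested in this assay. For the measured compounds named here, compound 3 is the one without a number: in this assay it was reported as not active, so it stands at the weak end, with no figure to set a baseline. Compound 4, `Cc1ccc(C2=NOC(C)(C)C2=O)cc1-c1cnc(NC(=O)c2ccccc2Cl)cn1`, differs from compound 3 by 2-chlorophenyl in place of 2,4-difluorophenyl on a carbonyl carbon. Going by the values given here, no measured pair shows this change, so neither the size nor the direction of the step in this assay is known from the data. Starting from an inactive compound 3, compound 4 is expected to remain weak, with an estimated half-maximal inhibitory concentration of 3000 nM, in a range from 400 nM to 20000 nM, and a real chance that only a limit is reported.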

Compound 4, half-maximal inhibitory concentration: 171 nM
Compound 4: middle estimate off by 18-fold (1.24 log units), on the high side, and the stated range ends above it.
By their numbers in this assay, from the lowest: compound 1; then compounds 2 and 4 (each within the scatter of the next).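

For the compounds shown here, compound 3 carries only the report "not active" and no number, so no step to compound 4 can be read. What 2-chlorophenyl in place of 2,4-difluorophenyl does stays open, and nothing shown explains the result.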